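Swapping benzyl for benzyloxy on a growth-inhibiting amine

A few compounds are considered here, and "the series" means these few. Any claim that something is new, unique, unknown or untested is made for them only; others in the source may bear on it.

Measured in an ADME assay on RAW264.7 cells (Mus musculus) for cytotoxicity, read by trypan blue exclusion, with a stated time of 48 h; a lower number here means a stronger inhibitor of growth, a higher number a weaker inhibitor of growth:
Compound 1 `Cc1c(CNCc2ccccc2)cc(-c2ccc(Cl)cc2)n1-c1ccc(Cl)cc1` gives "not determined" (no result reported)
Compound 2 `Cc1cc(CNCc2ccccc2)c(C)n1-c1ccc(F)cc1` gives 5.6 ug/mL

Within the data shown here, only one real number is available so far. Compound 2 stands alone at 5.6 ug/mL, and compound 1 offers no result to compare it with. Among the measured compounds shown here, the two measured compounds also differ in more than one place, so they provide no single-change step to serve as a guide.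

The next compound, compound 3 `Cc1cc(CNOCc2ccccc2)c(C)n1-c1ccc(F)cc1`, keeps everything in compound 2 except for one change, with benzyloxy in place of benzyl on an amine nitrogen. Nothing measured here shows how this swap behaves in this assay. The expectation therefore rests on compound 2 at 5.6 ug/mL alone, and the range must stay wide. A small move toward weaker growth inhibition is expected, hardly beyond the usual scatter, and the expected change is a 1.4-fold higher number from compound 2 to compound 3 (0.15 log units; within the scatter). For compound 3 the estimated value is 8 ug/mL, with an expected range from 3 ug/mL to 22 ug/mL.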

Compound 3, concentration for 50% growth inhibition: 123 ug/mL
The estimate for compound 3 lay 15-fold (1.19 log units) below the measured number; measured number above the stated range.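

In this assay, benzyloxy in place of benzyl on an amine nitrogen gives a 22-fold higher number from compound 2 to compound 3 (1.34 log units; beyond the scatter), so this is a large loss of growth inhibition. Among these compounds, this single-change step is the first, and it shows that the place is highly sensitive to this swap: the two groups share the same six-membered aromatic ring of carbon, yet the oxygen that benzyloxy brings, with its hydrogen-bond acceptor, goes with a change far beyond the usual scatter. No accompanying measurement on these compounds explains the size of this jump, so the step records what happens and not why it happens.

On these data alone, it remains open whether the oxygen itself matters or whether any longer link would do the same, and a phenethyl group on this amine nitrogen, with a carbon where benzyloxy has its oxygen, would separate those two readings. Also unsettled is whether benzyloxy in place of benzyl would act alike on the core of compound 1, which carries chlorophenyl groups, since one pair of compounds cannot show how far this step holds across the series.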